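The compounds below may be only part of what the source reports. "The series", "measured", "known", "first", "only" and "open" are said of these compounds alone.

Of the compounds shown here, three with a shared core have been measured in a functional assay on the whole organism with Mus musculus as the target; a lower number here means that less compound is needed, a higher number that more compound is needed for the effect. Compound 1 `O=C(/C=C1\CCc2cc(F)cc(F)c21)NC1CC1` gives 69 mg/kg, compound 2 `NC(=O)/C=C1\CCc2cc(F)cc(F)c21` gives 44 mg/kg and compound 3 `Cc1cccc2c1/C(=C/C(N)=O)CC2` gives 82 mg/kg. Compound 2 therefore stands within the scatter of both other compounds, and the three numbers do not separate it from them.

Compound 4 `NC(=O)/C=C1\CCc2cc(F)ccc21` differs from compound 2 in one place: hydrogen in place of fluoro on an aromatic carbon. This is hydrogen in place of fluoro on an aromatic carbon, ortho to a fused ring and meta to a fluoro group.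

Only one measured step links two of these compounds, a 1.6-fold lower number from compound 1 to compound 2 (0.20 log units; within the scatter), and it lies within the scatter. That step concerns an amide-type nitrogen, however, so it bears only indirectly on a change at an aromatic carbon. Among the measured compounds shown here, no measured step removes a fluoro group alone. Compound 3, which has no fluoro group and carries a methyl group, gives 82 mg/kg, still within the scatter of compound 2. The data therefore offer no ground for expecting a real shift in either direction in this assay.

The expected change is a 1.1-fold higher number from compound 2 to compound 4 (0.06 log units; within the scatter), which is not expected to exceed the scatter. For compound 4 the estimated value is 50 mg/kg, with an expected range from 25 mg/kg to 100 mg/kg.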

Compound 4, dose for half-maximal effect: 56 mg/kg
Beside the measured number, compound 4's estimate is 1.1-fold (0.05 log units) below it; the range from low to high includes it.
By their numbers in this assay, from the lowest: compounds 2, 4, 1 and 3 (each within the scatter of the next).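

In this assay, among the compounds shown here, the exchange of hydrogen for fluoro on an aromatic carbon, ortho to a fused ring and meta to a fluoro group, can now be read directly: it gives a 1.3-fold higher number from compound 2 to compound 4 (0.10 log units; within the scatter), the first measured step at this position. The earlier compounds shown here offered only a step on an amide-type nitrogen and a compound that differs in more than one place, whereas this pair isolates the fluoro group at this position and shows no effect beyond the scatter while the other fluoro group remains in place. No information on hand explains this result or shows what the fluoro group does at this position.

On these data alone, it remains open whether a larger or different group at this position, such as chloro, methoxy or a nitrile, would also give a step within the scatter. As far as these compounds go, it is equally open what the remaining fluoro group contributes alone, and whether the exchange would read the same way with the cyclopropyl group on the amide-type nitrogen.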